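Bromo to Nitrooxy on the Amide Side Chain: Compound 4

This account rests on a few compounds, and the source may have more. Where it says the series, first, only, none or still open, it means among the compounds named here.

Measured compounds:
Compound 1, `O=C(CBr)Nc1ccc(C(=O)/C=C/c2ccco2)cc1`: 37%
Compound 2, `O=C(CO[N+](=O)[O-])Nc1ccc(C(=O)/C=C/c2ccco2)cc1`: 36%
Compound 3, `CC(Br)C(=O)Nc1ccc(C(=O)/C=C/c2ccc(Cl)cc2)cc1`: 45%

All three compounds were tested in a functional assay on the whole organism (strain albino) for inhibition, with Rattus norvegicus as the target, read by paw edema, with stated times of 30 min and 2 h, at a dose of 100 mg/kg by the oral route; a lower number here means less inhibition, a higher number more inhibition at the dose given (going by the name of the read-out). Compound 1 gives 37% in this assay. Compound 2 differs from compound 1 in one place only: nitrooxy in place of bromo on a saturated chain carbon bound to a carbonyl carbon. This change made a step of a number 1 percentage points lower from compound 1 to compound 2 (within the scatter), so the two numbers cannot be told apart.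

Compound 3 is built on a different core, and the difference between its core and the core of compound 1 is not broken down here. In this assay compound 3 gives 45%. Its number is the highest of the three, but it lies within the scatter of both compound 1 and compound 2, so no order among the three can be claimed.

Compound 4, `CC(O[N+](=O)[O-])C(=O)Nc1ccc(C(=O)/C=C/c2ccc(Cl)cc2)cc1`, has not been measured. It differs from compound 3 by nitrooxy in place of bromo on a saturated chain carbon bound to a carbonyl carbon and a saturated chain carbon. For the measured compounds named here, this is the same kind of change as the one from compound 1 to compound 2, though here the carbon carrying the group is bound to a carbonyl carbon and also to a saturated chain carbon, whereas in compound 1 it is bound to a carbonyl carbon alone. Since the earlier step was a number 1 percentage points lower from compound 1 to compound 2 (within the scatter), a step of about a number 1 percentage points lower from compound 3 to compound 4 (within the scatter) is expected from compound 3 to compound 4, resting on that single observed pair. Compound 4 is therefore expected to give about 44% in this assay, with a likely range from 32% to 56%.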

Compound 4, a percentage reported as inhibition, in the whole organism at one dose (the size of the read-out at that dose, not a potency): 55%
Compound 4: the middle estimate sits 11 percentage points below what was measured, and the stated range covers the measured number.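

On the core of compound 3, putting nitrooxy in place of bromo gives a step of a number 10 percentage points higher from compound 3 to compound 4 (within the scatter) in this assay, so compound 3 and compound 4 cannot be told apart, just as compound 1 and compound 2 could not. Set side by side, the two steps do not differ by more than repeated measurements of this kind would be expected to: the same change on two cores in this assay, a number 1 percentage points lower (within the scatter) from compound 1 to compound 2 and a number 10 percentage points higher (within the scatter) from compound 3 to compound 4, 11 percentage points apart, within the scatter of two such steps

Within these two pairs, then, the swap gives no step that stands clear of the scatter on either core, and nothing here shows that the core alters its outcome; this does not prove that the swap has no effect or that it would act alike on both cores, as two pairs at a single dose are too few to settle either point.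

The compounds shown leave open whether another group at this place, such as an amine, a carboxylic acid or a longer chain, would give a step beyond the scatter. They also leave open how the swap from bromo to nitrooxy would behave on further cores, or how these compounds would read at other doses.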